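The source may report more compounds than this note shows. Statements on the series, on what has been measured and on what is new or still open speak of the compounds shown alone.

In a functional assay on HCT-116 cells (Homo sapiens) for cytotoxicity (a lower number here means a stronger inhibitor, a higher number a weaker inhibitor), compound 1 `COC(=O)C[C@@H]1CCCN1CCC/C=C1\C=C(C)C(=O)O1` gives > 5 ug/mL as a limit and not a number. Compound 2 `COC(=O)C[C@H]1CCCN1CCC/C=C1\C=C(C)C(=O)O1` gives > 5 ug/mL as a limit too, so compound 2 holds no readable place on the scale. For the measured compounds named here, the only measured step is a step that the two limits leave unreadable from compound 1 to compound 2 and it concerns a stereocentre at a saturated ring carbon, drawn S in compound 1 and R in compound 2. Its size cannot be read because of the limit of > 5 ug/mL in this assay, at which 2 of the 2 values shown sit, and so it offers no measure to carry forward.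

Compound 3 `COC(=O)C[C@H]1CCCN1CCC/C=C1/C=C(C)C(=O)O1` stands to compound 2 as follows: the two compounds have the same atoms and bonds and differ only in configuration as drawn: 1 of 2 stereo elements differ; a double bond is drawn E in compound 2 and Z in compound 3 and thus a double bond is drawn E in compound 2 and Z in compound 3. Going by the values given here, no measured step touches that double bond. Since compound 2 has only the limit > 5 ug/mL to show, no step beyond the scatter is expected in this assay and no direction can be argued. The expected step is a step that the limit leaves unreadable from compound 2 to compound 3 and it rests on little. Compound 3 is estimated at 8 ug/mL with an expected range from 4 ug/mL to 20 ug/mL and the assay may well report only a limit again.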

Compound 3, half-maximal inhibitory concentration: > 5 ug/mL
Compound 3 ended at the assay's limit (the forecaster's own chance of this, stated with the estimate: 85%); the middle value lies beyond the limit too.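

In this assay compound 3 gives > 5 ug/mL, a limit and not a number. The steps linking compound 3 to compound 1 and to compound 2 therefore cannot be read: the limit of > 5 ug/mL in this assay, at which 3 of the 3 values shown sit. The compounds shown leave open whether the configuration of the saturated ring stereocentre or of the double bond changes the read-out in this assay at all.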